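The compounds below may be only part of what the source reports. "The series", "measured", "known", "first", "only" and "open" are said of these compounds alone.

The compounds measured so far:
compound 1, `COc1ccc(-c2cn3cc(C4=CCN(C(=O)c5ccccc5C(F)(F)F)CC4)ccc3n2)cc1OC`, 2550 nM
compound 2, `COc1ccc(-c2cn3cc(C4=CCN(C(=O)c5ccc(Cl)cc5)CC4)ccc3n2)cc1OC`, 8970 nM

Both were tested in a functional assay on A549 cells (Homo sapiens) for antiproliferative activity, read by MTT assay, with a stated time of 48 h; a higher number here means a weaker inhibitor, a lower number a stronger inhibitor. Going by the values given here, compound 2 gives the higher of the two numbers; its only neighbour is compound 1, and the step of a 3.5-fold higher number from compound 1 to compound 2 (0.55 log units; beyond the scatter) goes with one change on the carbonyl carbon, 4-chlorophenyl in place of 2-(trifluoromethyl)phenyl. Compound 3, `COc1ccc(-c2cn3cc(C4=CCN(C(=O)c5ccccc5)CC4)ccc3n2)cc1OC`, has not been measured yet. It differs from compound 2 by hydrogen in place of chloro on an aromatic carbon, para to a large group. Among the compounds with values here, no measured step removes a chloro from this ring, so the one step available, a 3.5-fold higher number from compound 1 to compound 2 (0.55 log units; beyond the scatter), bears only loosely: it shows that altering the group on the carbonyl carbon moved the number by a modest amount. For compound 3 a step within the scatter, or slightly upward, is expected, a 1.2-fold higher number from compound 2 to compound 3 (0.09 log units; within the scatter). Compound 3 is therefore estimated at 11000 nM, in the range 4500 nM to 27000 nM.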

Compound 3, half-maximal inhibitory concentration: 7700 nM
Compound 3: the middle estimate sits 1.4-fold (0.15 log units) above what was measured; measured number inside the range.
By their numbers in this assay, from the lowest: compound 1; then compounds 3 and 2 (each within the scatter of the next).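

In this assay, taking away the chloro gives a 1.2-fold lower number from compound 2 to compound 3 (0.07 log units; within the scatter) and so leaves the 4-chlorophenyl and phenyl groups on the carbonyl carbon indistinguishable here. With the plain phenyl now in hand as a reference, the trifluoromethyl group can be judged alone: its replacement by hydrogen gives a 3.0-fold higher number from compound 1 to compound 3 (0.48 log units; beyond the scatter) and marks it, among these three compounds, as the one substituent that goes with a clear difference in the number. No outside measurement is available to explain either result.

Still open, from the compounds shown here alone, is how other groups in the chloro's place, para to a large group, such as an amine or a carboxylic acid, would read. Also open, going by these compounds, is whether a methyl or a chloro in the trifluoromethyl group's place would keep the lower number of compound 1.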